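Ester Swap on a Dihydropyridine Calcium Channel Blocker

The source may hold more compounds than are shown below. What is called first, only, known or untested is meant among the compounds shown, and "the series" means these compounds.

Compound 1 `CSc1ncc(C2C(C(=O)OC3CCCC3)=C(C)NC(C)=C2C(=O)OC2CCCC2)n1Nc1ccccc1`: 425 nM
Compound 2 `CSc1ncc(C2C(C(=O)OC(C)C)=C(C)NC(C)=C2C(=O)OC(C)C)n1Nc1ccccc1`: 2.16 nM
Compound 3 `COC(=O)C1=C(C)NC(C)=C(C(=O)OCc2ccccc2)C1c1cnc(SC)n1Nc1ccccc1`: 2.21 nM

Three compounds sharing one core were tested in an assay on isolated protein (strain albino) for antagonist activity at Voltage-dependent L-type calcium channel subunit alpha-1C (Cavia porcellus); a higher number here means a weaker inhibitor, a lower number a stronger inhibitor. Compound 2 shows the lowest number of the three, with its 2.16 nM. Compound 3 sits at 2.21 nM, a number within the usual scatter of that of compound 2, so the two cannot be told apart. Compound 1, which carries a cyclopentyl ester on each side of the core, gives 425 nM, a far higher number than compound 2 that lies well beyond the scatter.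

Compound 4 `CSc1ncc(C2C(C(=O)OCC3CCCCC3)=C(C)NC(C)=C2C(=O)OC(C)C)n1Nc1ccccc1` is not yet measured. It differs from compound 2 in one place: cyclohexylmethyl in place of isopropyl on an oxygen next to a carbonyl group. One ester of compound 2 is kept, the other grows from a three-carbon branch to a seven-carbon group with a ring.

Among the compounds with values here, no directly measured step of this kind is available. Compound 3 shows that one larger ester beside a small one can keep the number low, while compound 1 shows that two ring-bearing esters give a much higher number. A modest rise is therefore expected for compound 4, of the size a 2.8-fold higher number from compound 2 to compound 4 (0.44 log units; beyond the scatter). Compound 4 is estimated at 6 nM in this assay, with a likely range from 1.5 nM to 30 nM.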

Compound 4, half-maximal inhibitory concentration: 56 nM
Compound 4: middle estimate off by 9.3-fold (0.97 log units), on the low side; measured number above the stated range.
By their numbers in this assay, from the lowest: compounds 2 and 3 (each within the scatter of the next); then compound 4; then compound 1.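

Within the data shown here, compound 4 gives the first direct reading of a single change in this set: with the core and one isopropyl ester held fixed, placing cyclohexylmethyl on the other ester oxygen gives, in this assay, a 26-fold higher number from compound 2 to compound 4 (1.41 log units; beyond the scatter). This step is large and lies beyond the scatter, so replacing one ester group is enough on its own to move the number substantially. Compounds 1, 2 and 3 could not show this, as each pair among them differs in more than one place, and nothing available explains why this step is so large.

From the compounds shown here alone, it remains open whether the ring itself or the larger number of carbons matters more, and an open heptyl chain or a smaller cyclopropylmethyl group on the same oxygen would help separate those two readings. An ester carrying an amine, such as dimethylaminoethyl, would test a different kind of group at this position, and how it would compare with the isopropyl of compound 2 cannot be told from the compounds shown.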